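A few compounds are considered here, and "the series" means these few. Any claim that something is new, unique, unknown or untested is made for them only; others in the source may bear on it.

Two compounds from one series are already measured. Compound 1 `O=C1OC(c2ccc(OCc3ccccc3)cc2)C(c2ccc(O)cc2)=C1O` gives 0% in an assay on blood for inhibition of Polyunsaturated fatty acid 5-lipoxygenase (Homo sapiens), tested at 10 uM (on this read-out higher numbers stand for a stronger effect at the one concentration tested and lower numbers for a weaker effect), while compound 2 `O=C1OC(c2ccc(O)c(O)c2)C(c2ccc(O)cc2)=C1O` gives 35.4% in this assay, which makes compound 2 the higher of the two numbers, and the gap between these two values lies beyond the usual scatter of repeated measurements.

Compound 3 `O=C1OC(c2ccc(O)cc2)C(c2ccc(O)cc2)=C1O` shares the core of compound 2 and differs in one place: hydrogen in place of hydroxy on an aromatic carbon. Within the data shown here, no pair of measured compounds shows this exact change, so its effect is not yet known from a measured step.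

My expectation for compound 3 in this assay is a drop of moderate size, the step of a number 25.4 percentage points lower from compound 2 to compound 3 (beyond the scatter), because compound 1 with its single-hydroxy ring reached only 0% while the second hydroxy in compound 2 coincides with the higher value. For compound 3 I therefore estimate 10%, within a range from 0% to 30%.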

Compound 3, a percentage reported as activity, at one concentration (the size of the read-out at that concentration, not a potency): 0%
Compound 3: the middle estimate sits 10 percentage points above what was measured; low and high end bracket the measured number.
By their numbers in this assay, from the lowest: compounds 1 and 3 (each within the scatter of the next); then compound 2.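

Taking the hydroxy group off this aromatic carbon gives a large loss in this assay, with a number 35.4 percentage points lower from compound 2 to compound 3 (beyond the scatter) as the measured step, so the effect seen in this small set depends on having this hydroxy group in place. Hydrogen in place of benzyl on the oxygen gives no change at the digits printed from compound 1 to compound 3 (within the scatter) as its step, so without this hydroxy group, neither form of that oxygen shows any effect at the concentration tested. Nothing available here explains why this hydroxy group matters.

From the compounds shown here alone, it remains open whether a different group on this carbon, such as a methoxy group, an amine or a fluorine atom, could keep any of the effect. Going by these compounds, whether benzyl on the oxygen changes the read-out when this hydroxy group is present also remains open.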